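Extending the Amide Chain of Compound 2

This account rests on a few compounds, and the source may have more. Where it says the series, first, only, none or still open, it means among the compounds named here.

Compound 1 `CC(=O)N[C@H]1[C@@H](OCCCCc2ccccc2)O[C@H](CO)[C@@H](O)[C@@H]1O`: > 50 uM
Compound 2 `CCCCCCCCCCCCCCCCO[C@H]1O[C@H](CO)[C@@H](O)[C@H](O)[C@H]1NC(C)=O`: 13 uM
Compound 3 `C=CCCC(=O)N[C@H]1[C@@H](OCCc2ccccc2)O[C@H](CO)[C@@H](O)[C@@H]1O`: > 50 uM

Of the compounds shown here, three have been tested in a functional assay on C6 cells (Rattus norvegicus), read by thymidine incorporation; a lower number here means a stronger inhibitor, a higher number a weaker inhibitor. Compound 1 reaches only a limit of the assay, > 50 uM. Compound 3 likewise reaches only a limit, > 50 uM. Going by the values given here, compound 2 is the one compound for which a number exists: in this assay compound 2 gives 13 uM. Compound 2 therefore stands as the single measured point from which to reason; the two other values sit at the limit of > 50 uM in this assay, at which 2 of the 3 values shown sit, and no pair of measured compounds differs in a single place, so no step has been quantified.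

Compound 4 `C=CCCC(=O)N[C@H]1[C@@H](OCCCCCCCCCCCCCCCC)O[C@H](CO)[C@@H](O)[C@@H]1O` has not been measured. It differs from compound 2 in one place: allyl in place of hydrogen on a saturated chain carbon bound to a carbonyl carbon. Among the compounds with values here, no measured step reports the effect of this change on the shared core, and the two limit values give no direction. The expected step from compound 2 to compound 4 is a 1.3-fold lower number from compound 2 to compound 4 (0.11 log units; within the scatter), which the writer takes as a small movement that may fall within the usual scatter. Compound 4 is accordingly estimated at 10 uM, with a likely range from 3 uM to 40 uM.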

Compound 4, concentration for 50% inhibition: > 50 uM
Compound 4 was reported as a limit (the forecaster's own chance of this, stated with the estimate: 15%); middle value at least 5.0-fold (0.69 log units) from the limit.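

Allyl in place of hydrogen on a saturated chain carbon bound to a carbonyl carbon, which turns acetamido into ((but-3-en-1-yl)carbonyl)amino, gives an at least 3.8-fold higher number from compound 2 to compound 4 (0.58 log units; beyond the scatter) in this assay, and this is the first step in the series that can be read at all. In this assay compound 4 gives > 50 uM, which is a limit and not a number. The position is therefore not indifferent to change: with the rest of compound 2 left as it is, this longer acyl group moves the number towards weaker inhibition, by an amount that has only a lower bound, and the one measured value in the series now stands alone: the limit of > 50 uM in this assay, at which 3 of the 4 values shown sit.

The compounds shown leave open whether the loss comes with chain length as such or with the terminal double bond, which a saturated pentanoyl group on the same nitrogen could separate. They also leave open whether a shorter propionyl group would keep the value of compound 2, and whether an amine or a carboxylic acid at the end of the acyl chain would read differently.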